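The source may hold more compounds than are shown below. What is called first, only, known or untested is meant among the compounds shown, and "the series" means these compounds.

Within the data shown here, compound 3 `NC(=O)c1c(NC(=O)c2ccccc2Cl)sc2c1CCN(Cc1cc(Cl)cc(Cl)c1)C2` carries a 3,5-dichlorobenzyl group on an amine nitrogen in a ring; in a functional assay on HeLa cells (Homo sapiens) for antiproliferative activity, with a stated time of 24 h (a lower number here means a stronger inhibitor, a higher number a weaker inhibitor), compound 3 gives 19600 nM, the only number among the three values shown. Compound 1 `NC(=O)c1c(NC(=O)c2ccccc2Cl)sc2c1CCN(Cc1ccccc1F)C2` gives > 50000 nM, which is a limit of the assay rather than a number. Compound 2 `NC(=O)c1c(NC(=O)c2ccccc2Cl)sc2c1CCN(Cc1ccc(Cl)cc1)C2` likewise gives > 50000 nM, again a limit. Moving from the 2-fluorophenyl of compound 1 to the 3,5-dichlorophenyl of compound 3 gave an at least 2.5-fold lower number from compound 1 to compound 3 (0.40 log units; beyond the scatter), and the corresponding move from compound 2 gave an at least 2.5-fold lower number from compound 2 to compound 3 (0.40 log units; beyond the scatter). The step that the two limits leave unreadable from compound 1 to compound 2 cannot be read because of the limit of > 50000 nM in this assay, at which 2 of the 3 values shown sit.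

Compound 4 `COc1ccccc1NC(=S)N1CCc2c(sc(NC(=O)c3ccccc3Cl)c2C(N)=O)C1` differs from compound 3 in the group on that same nitrogen: a group of 11 heavy atoms (8 carbon, 1 nitrogen, 1 oxygen, 1 sulfur; one six-membered aromatic ring of carbon only) in place of a group of 9 heavy atoms (7 carbon, 2 chlorine; one six-membered aromatic ring of carbon only), on an amine nitrogen in a ring. Among the measured compounds shown here, no measured step removes the 3,5-dichlorobenzyl group altogether or brings in the entering group, so none bears on this change directly; what the data show is that two of three substituents at this position gave only a limit and the third gave a weak number. Compound 4 is therefore expected to sit near that limit, with an expected step of a 1.8-fold higher number from compound 3 to compound 4 (0.25 log units; within the scatter). The estimate for compound 4 is 35000 nM, in a range from 10000 nM to 120000 nM.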

Compound 4, half-maximal inhibitory concentration: > 50000 nM
Compound 4: no number, only a limit; the forecaster's own chance of this, stated with the estimate: 50%; middle value at least 1.4-fold (0.15 log units) from the limit.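

Among these compounds, replacing the 3,5-dichlorobenzyl group on the amine nitrogen in a ring with the larger group that is not a substituted benzyl gave an at least 2.5-fold higher number from compound 3 to compound 4 (0.40 log units; beyond the scatter) in this assay, so the one readable number at this position did not carry over to this different kind of substituent. Compound 4 gives > 50000 nM, which is a limit of the assay and not a number. The steps to compound 4 from compound 1 and from compound 2 cannot be read, and compound 3 remains the only compound here with a number, so the position offers a single value and no graded series: the limit of > 50000 nM in this assay, at which 3 of the 4 values shown sit.

The compounds shown leave open whether the gain of compound 3 depends on having both chlorines, as a 3-chlorobenzyl group or an unsubstituted benzyl group on the same nitrogen could show. They also leave open which part of the entering group goes with the loss, since neither a version with a carbonyl oxygen in place of the sulfur nor one lacking the methoxy group appears among them.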